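The compounds below may be only part of what the source reports. "The series", "measured", "known", "first", "only" and "open" are said of these compounds alone.

In a functional assay on DU-145 cells (Homo sapiens) for antiproliferative activity, read by sulforhodamine B assay, with a stated time of 3 days (a higher number here means a weaker inhibitor of growth, a lower number a stronger inhibitor of growth), compound 1 (`COc1ccc(NC(=O)c2cccc(Nc3ncc(F)c(Nc4ccc(F)cc4)n3)c2)cc1`) gives > 10000 nM, which is a limit of the assay and not a number. Compound 2 (`CN1CCC(C(=O)Nc2cccc(Nc3ncc(F)c(Nc4ccc(F)cc4)n3)c2)CC1`) gives 1150 nM. Within the data shown here, the only measured step, an at least 8.6-fold lower number from compound 1 to compound 2 (0.93 log units; beyond the scatter), puts ((1-methylpiperidin-4-yl)carbonyl)amino in place of (4-methoxyphenyl)carbamoyl on an aromatic carbon, so it removes the whole amide-linked group and bears only loosely on the next change. Compound 3 (`COc1cc(NC(=O)c2cccc(Nc3ncc(F)c(Nc4ccc(F)cc4)n3)c2)cc(OC)c1`) has 3,5-dimethoxyphenyl in place of 4-methoxyphenyl on an amide-type nitrogen. The reference for compound 1 is only (the limit of > 10000 nM in this assay, at which 1 of the 2 values shown sits), so no step beyond the scatter is expected in this assay. The expected step is a number no higher from compound 1 to compound 3 (the limit leaves the size open). Compound 3 is estimated at 10000 nM, with an expected range of 3000 nM to 30000 nM.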

Compound 3, concentration for 50% growth inhibition: 13700 nM
Compound 3: middle estimate off by 1.4-fold (0.14 log units), on the low side, within the range that was stated.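

Among these compounds, no step from compound 1 to compound 3 can be read, since the value of compound 1 is a limit of the assay and not a number: the limit of > 10000 nM in this assay, at which 1 of the 3 values shown sits. The compounds shown leave open whether 3,5-dimethoxyphenyl in place of 4-methoxyphenyl on the amide-type nitrogen changes growth inhibition at all.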